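The source may hold more compounds than are shown below. What is called first, only, known or untested is meant among the compounds shown, and "the series" means these compounds.

Compound 1 `COc1ccc(CNc2cc(OC)c(OC)c(OC)c2)cc1Cl` and compound 3 `COc1ccc(CNc2cc(OC)c(OC)c(OC)c2)cc1Br` are built on one core, while compound 2 `COc1cc(NCc2ccc(Cl)cc2)cc(OC)c1OC` and compound 4 `COc1cc(NCc2ccc(Br)cc2)cc(OC)c1OC` are built on another; how the two cores differ is not broken down here. In a functional assay on MGC-803 cells (Homo sapiens) for inhibition, read by MTT assay, with a stated time of 48 h (a lower number here means a stronger inhibitor, a higher number a weaker inhibitor), compound 1 gives 46200 nM. In this assay compound 3 gives 29400 nM. The change from compound 1 to compound 3 is bromo in place of chloro on an aromatic carbon and it made a 1.6-fold lower number from compound 1 to compound 3 (0.20 log units; within the scatter). For compound 2 this assay reports only a limit, > 80000 nM, not a number. This is the limit of > 80000 nM in this assay, at which 1 of the 3 values shown sits.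

Compound 4 has not yet been measured in this assay. It differs from compound 2 by bromo in place of chloro on an aromatic carbon. Among the measured compounds shown here, this is the same kind of change as the one from compound 1 to compound 3, but the place is not the same: in compound 1 the changed carbon is ortho to a methoxy group and meta to a large group, whereas in compound 2 it is para to a large group.

Compound 4 is therefore expected to give about 80000 nM in this assay, with a range from 35000 nM to 200000 nM, and it is expected that the assay may again report only a limit. This expectation means a number no higher from compound 2 to compound 4 (the limit leaves the size open). It rests on the measured step of a 1.6-fold lower number from compound 1 to compound 3 (0.20 log units; within the scatter), which stayed within the scatter, so the same kind of change is expected to leave compound 4 near where compound 2 stands.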

Compound 4, half-maximal inhibitory concentration: > 80000 nM
Compound 4: no number, only a limit; the forecaster's own chance of this, stated with the estimate: 60%; the middle value lies on the limit itself.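

Compound 4, like compound 2, is reported only as a limit, and no step can be read from compound 2 to compound 4 because both sit at the same limit: the limit of > 80000 nM in this assay, at which 2 of the 4 values shown sit.

The compounds shown leave open how far the change from 4-chlorophenyl to 4-bromophenyl moves the number in this assay and whether it matches the change between compound 1 and compound 3 on the other core.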